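From acetoxy to methoxy in a growth inhibition test

The source may hold more compounds than are shown below. What is called first, only, known or untested is meant among the compounds shown, and "the series" means these compounds.

Going by the values given here, in a functional assay on HeLa cells (Homo sapiens) for inhibition, with a stated time of 48 h, tested at 30 uM (a lower number here means less inhibition of growth, a higher number more inhibition of growth at the concentration tested), compound 1 `C=C[C@@](C)(/C=C/c1ccc(OC(C)=O)cc1)CCC=C(C)C` gives 45%, the higher of the two numbers available so far. Compound 2 `C=C[C@@](C)(/C=C/c1ccc(OC(=O)CCCCCCCCC)cc1)CCC=C(C)C`, with octyl in place of hydrogen on a saturated chain carbon bound to a carbonyl carbon, gives 24%. Compound 3 `C=C[C@@](C)(/C=C/c1ccc(OC)cc1)CCC=C(C)C` has not yet been measured in this assay. Its change from compound 1 is methyl in place of acetyl on an oxygen on an aromatic ring. Among the compounds with values here, only one measured step offers any guide, and a loose one: a number 21 percentage points lower from compound 1 to compound 2 (beyond the scatter). That step extends the acetyl chain and keeps the carbonyl, whereas compound 3 replaces the whole acetyl, so neither its size nor its direction carries over directly. With so little evidence, the expected outcome is a number 5 percentage points lower from compound 1 to compound 3 (within the scatter). Compound 3 is expected to give 40%, with an estimated range from 20% to 60%.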

Compound 3, percent growth inhibition at one concentration: 28%
The estimate for compound 3 lay 12 percentage points above the measured number; the range from low to high includes it.
By their numbers in this assay, from the lowest: compounds 2 and 3 (each within the scatter of the next); then compound 1.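

In this assay, methyl in place of acetyl on an oxygen on an aromatic ring gives a number 17 percentage points lower from compound 1 to compound 3 (beyond the scatter). The earlier compounds shown here showed only that lengthening the acyl chain, with its carbonyl kept, lowers the number, as in a number 21 percentage points lower from compound 1 to compound 2 (beyond the scatter); this result shows that a change which removes the carbonyl altogether also lowers it. Compound 2 and compound 3 lie within the scatter of each other, so in this small set, both changes away from the acetoxy group end at about the same level, and compound 1 stays the highest.

No measurement available here explains the lower number for compound 3. As far as these compounds go, it remains open whether a hydroxyl group, a propionyl group or a longer ether chain on this oxygen would stay close to compound 1 or fall to the level of compound 2 and compound 3.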